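A few compounds are considered here, and "the series" means these few. Any claim that something is new, unique, unknown or untested is made for them only; others in the source may bear on it.

Compound 1, `Nc1ncn(Cc2ccccc2Cl)c2ncnc1-2`, compound 2, `Nc1ncn(Cc2cccc(Cl)c2)c2ncnc1-2`, and compound 3, `Cc1ccccc1Cn1cnc(N)c2ncnc1-2`, were each tested in an assay on isolated protein (adrenal medulla) for inhibition of Dopamine beta-hydroxylase (Bos taurus); on this read-out lower numbers stand for stronger inhibition and higher numbers for weaker inhibition. In this assay compound 1 gives 200 ug/mL, compound 2 gives 2 ug/mL and compound 3 gives 200 ug/mL. Compound 3 differs from compound 1 by methyl in place of chloro on an aromatic carbon, and this step, no change at the digits printed from compound 1 to compound 3 (within the scatter), left the read-out where it was. Compound 2 has the lowest number of the three, and compound 1 and compound 3 both lie well beyond the scatter above it. The difference between the cores of compound 1 and compound 2 is not broken down here.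

Compound 4, `Cc1cccc(Cn2cnc(N)c3ncnc2-3)c1`, has not yet been measured. It differs from compound 2 by methyl in place of chloro on an aromatic carbon. This is the same kind of change as from compound 1 to compound 3, but not the same: there the place was ortho to a large group, here it is meta to a large group. For compound 4 the expected step is a 5.0-fold higher number from compound 2 to compound 4 (0.70 log units; beyond the scatter), because no change at the digits printed from compound 1 to compound 3 (within the scatter) shows that the same kind of change did not move the number, while the starting point is now the lowest value and the place differs, so some loss is allowed for. Compound 4 is therefore estimated at 10 ug/mL, expected between 2 ug/mL and 60 ug/mL.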

Compound 4, half-maximal inhibitory concentration: 20 ug/mL
Compound 4: the middle estimate sits 2.0-fold (0.30 log units) below what was measured, and the stated range covers the measured number.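

In this assay, methyl in place of chloro gives a 10-fold higher number from compound 2 to compound 4 (1.00 log units; beyond the scatter), and the same change does not have the same size on the two cores: the same change on two cores in this assay, no change at the digits printed (within the scatter) from compound 1 to compound 3 and a 10-fold higher number (1.00 log units; beyond the scatter) from compound 2 to compound 4, 10-fold (1.00 log units) apart, beyond the scatter of two such steps

This means that the size of the change seen on one core could not be carried over to the other core here, and a newcomer's simple rule, that a given swap always shifts the number by the same amount, fails for these two pairs. It does not show why the two steps differ, and two pairs are too few to give a rule for what this change would do on any further core.

Going by these compounds, it remains open how the same change behaves on cores beyond these two, and whether the gap between the two steps would appear again there. Also open, on these data alone, is how other groups in the same place, such as an amine, a methoxy group or a carboxylic acid, compare with chloro and methyl.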